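One Side-Chain Change Carried Onto a Second Core

The source may report more compounds than this note shows. Statements on the series, on what has been measured and on what is new or still open speak of the compounds shown alone.

Measured compounds:
- Compound 1, `COc1ccc(C(=O)c2ccc3c(c2)C=CC(C)(C)O3)c(NC(=O)CO)c1`: in a functional assay on HCT-8 cells (Homo sapiens) for antiproliferative activity, read by MTT assay, with a stated time of 48 h (a higher number here means a weaker inhibitor, a lower number a stronger inhibitor), compound 1 gives 250 nM.
- Compound 2, `CNCC(=O)Nc1cc(OC)ccc1C(=O)c1ccc2c(c1)C=CC(C)(C)O2`: in this assay compound 2 gives 1010 nM.
- Compound 3, `COc1ccc(C(=O)c2cc(OC)c(OC)c(OC)c2)c(NC(=O)CO)c1`: in this assay compound 3 gives 120 nM.

Compounds 1 and 2 share one core and differ only in the side chain on the amide: methylamino in place of hydroxy on a saturated chain carbon bound to a carbonyl carbon. That change gave a 4.0-fold higher number from compound 1 to compound 2 (0.61 log units; beyond the scatter), so the methylamino compound is the weaker of the pair. Compound 3 carries a different core; the difference between the two cores is not broken down here. Compound 4, `CNCC(=O)Nc1cc(OC)ccc1C(=O)c1cc(OC)c(OC)c(OC)c1`, is not yet measured and stands to compound 3 as compound 2 stands to compound 1: methylamino in place of hydroxy on a saturated chain carbon bound to a carbonyl carbon. The place of the change is described in the same words for both pairs, so this is the same change made on a second core. The expectation for compound 4 in this assay rests on the step seen once before, a 4.0-fold higher number from compound 1 to compound 2 (0.61 log units; beyond the scatter), and the expected step from compound 3 is a 4.0-fold higher number from compound 3 to compound 4 (0.60 log units; beyond the scatter). Compound 4 is therefore estimated at 480 nM, likely between 200 nM and 1200 nM, pending the measurement.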

Compound 4, half-maximal inhibitory concentration: 780 nM
Beside the measured number, compound 4's estimate is 1.6-fold (0.21 log units) below it; measured number inside the range.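

In this assay, putting methylamino in place of hydroxy on the second core gave a 6.5-fold higher number from compound 3 to compound 4 (0.81 log units; beyond the scatter) and left the methylamino compound as the weaker of its pair, as on the first core. So in this series the change carried over from one core to the other in both direction and approximate size, but two pairs in a single cell assay do not show that a third core would behave the same way, and they do not explain why the methylamino compounds are weaker. Set side by side, the two steps agree as closely as measurements of this kind can show: the same change on two cores in this assay, a 4.0-fold higher number (0.61 log units; beyond the scatter) from compound 1 to compound 2 and a 6.5-fold higher number (0.81 log units; beyond the scatter) from compound 3 to compound 4, 1.6-fold (0.21 log units) apart, within the scatter of two such steps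

The compounds shown leave open what other groups would do on the same saturated chain carbon, such as a dimethylamino group, a primary amine, a carboxylic acid or a longer chain. They also leave open whether the same step would appear on other cell lines.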